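From pyrrolidin-1-yl to 4-methylpiperidin-1-yl: series notes

A few compounds are considered here, and "the series" means these few. Any claim that something is new, unique, unknown or untested is made for them only; others in the source may bear on it.

Of the compounds shown here, two with a shared core have been read so far in a functional assay on HepG2 cells (Homo sapiens) for antiproliferative activity, read by MTT assay, with a stated time of 72 h; a higher number here means a weaker inhibitor, a lower number a stronger inhibitor. Compound 1 `COc1cc2c(Nc3ccc(C#N)cc3)ncnc2cc1OCCCN(C)C` gives > 100000 nM, and this is a limit of the assay, not a number. Going by the values given here, compound 2 `COc1cc2c(Nc3ccc(C#N)cc3)ncnc2cc1OCCCN1CCCC1` gives 20900 nM, the only actual number available in this assay.

Next in line is compound 3 `COc1cc2c(Nc3ccc(C#N)cc3)ncnc2cc1OCCCN1CCC(C)CC1`, which has 4-methylpiperidin-1-yl in place of pyrrolidin-1-yl on a saturated chain carbon, three bonds along the chain from an oxygen on an aromatic ring.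

Among the compounds with values here, the only measured step that bears on this is an at least 4.7-fold lower number from compound 1 to compound 2 (0.67 log units; beyond the scatter), where pyrrolidin-1-yl replaced dimethylamino in the same place, so a further modest move toward a lower number is expected in this assay. Going by these compounds, the true size of that step stays open because of the limit of > 100000 nM in this assay, at which 1 of the 2 values shown sits. A single step between different groups is thin guidance, so the expectation is loose. The expected change is a 1.7-fold lower number from compound 2 to compound 3 (0.24 log units; within the scatter). For compound 3 the estimated value is 12000 nM, with an expected range from 4000 nM to 40000 nM.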

Compound 3, half-maximal inhibitory concentration: 32100 nM
Compound 3: the middle estimate sits 2.7-fold (0.43 log units) below what was measured; low and high end bracket the measured number.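

Replacing a five-membered ring with a six-membered ring carrying a methyl group gives no readable change at this position on the chain: in this assay, the step reads a 1.5-fold higher number from compound 2 to compound 3 (0.19 log units; within the scatter), so compound 2 and compound 3 cannot be told apart here, and the trend seen with the first ring amine does not continue. The step from dimethylamino to 4-methylpiperidin-1-yl reads an at least 3.1-fold lower number from compound 1 to compound 3 (0.49 log units; beyond the scatter), so in this assay this second ring amine also stands apart from dimethylamino, as pyrrolidin-1-yl does in the step of an at least 4.7-fold lower number from compound 1 to compound 2 (0.67 log units; beyond the scatter). Compound 1 is read only as a limit, not a number, and the true size of both steps from it stays open because of this: the limit of > 100000 nM in this assay, at which 1 of the 3 values shown sits.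

The two ring amines differ both in ring size and in the methyl group, so these compounds cannot show what either change does alone, and an unsubstituted piperidin-1-yl would address that directly. Going by these compounds, whether morpholin-4-yl, piperazin-1-yl or a shorter or longer chain carrying these ring amines would give a different reading also remains open.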